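Replacing the Piperidinyl Group with Hydroxy on the Pyrimidine Core

This account rests on a few compounds, and the source may have more. Where it says the series, first, only, none or still open, it means among the compounds named here.

Measured so far:
- compound 1, `O=C(Nc1cc(Cl)cc(Cl)c1)c1cnc(Cl)nc1C(F)(F)F`, gives 500 nM
- compound 2, `O=C(Nc1cc(Cl)cc(Cl)c1)c1cnc(N2CCCCC2)nc1C(F)(F)F`, gives 5000 nM

These two compounds share the same core and amide, and were tested in an assay on Jurkat cells for inhibition of nuclear factor NF-kappa-B p105 subunit (Homo sapiens); on this read-out lower numbers stand for stronger inhibition and higher numbers for weaker inhibition. For the measured compounds named here, compound 2 holds the highest number of the two, with compound 1 as its only neighbour at a clearly lower number. Going by the values given here, the single measured step is a 10-fold higher number from compound 1 to compound 2 (1.00 log units; beyond the scatter); it shows that bringing in the piperidin-1-yl group at this position raised the number well beyond the scatter.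

Compound 3, `O=C(Nc1cc(Cl)cc(Cl)c1)c1cnc(O)nc1C(F)(F)F`, is not yet measured. It differs from compound 2 in one place: hydroxy in place of piperidin-1-yl on an aromatic carbon. Among the compounds with values here, the change removes the group that was brought in by the one measured step, so that step bears on it in reverse, yet the hydroxy group that enters is not the chloro that was there before, so a full return to the number of compound 1 cannot simply be assumed. A number between the two measured values seems the most plausible outcome, leaning toward a lower number, estimated as a 4.2-fold lower number from compound 2 to compound 3 (0.62 log units; beyond the scatter). Compound 3 is therefore expected to give about 1200 nM, within a range from 300 nM to 5000 nM.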

Compound 3, half-maximal inhibitory concentration: > 10000 nM
Compound 3: no number, only a limit (the forecaster's own chance of this, stated with the estimate: 10%); middle value at least 8.3-fold (0.92 log units) away from the limit.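

In this assay compound 3 carries a limit of the assay rather than a number, and every comparison with it rests on that: the limit of > 10000 nM in this assay, at which 1 of the 3 values shown sits. Putting hydroxy in place of piperidin-1-yl gives an at least 2.0-fold higher number from compound 2 to compound 3 (0.30 log units; that floor lies within the scatter), so removing the piperidin-1-yl group does not recover the lower number of compound 1, although this floor alone does not separate compound 3 from compound 2. The clearer finding comes from the change at the same position of hydroxy in place of chloro, which gives an at least 20-fold higher number from compound 1 to compound 3 (1.30 log units; beyond the scatter); among the three compounds shown, chloro therefore goes with the lowest number, and the number does not simply follow the count of heavy atoms in the group, since both the larger piperidin-1-yl and the smaller hydroxy go with clearly higher numbers.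

The compounds shown leave open how far beyond the limit compound 3 really lies, and so whether it truly differs from compound 2. They also leave open whether a primary amine, a methoxy group or a fluoro group at this position would keep the number of compound 1 or lose it as well.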